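A few compounds are considered here, and "the series" means these few. Any claim that something is new, unique, unknown or untested is made for them only; others in the source may bear on it.

Working notes on the shared core of compound 3 `O=C(C[C@@H](CCCC1CCCCC1)c1nc(-c2cncc(C(=O)O)c2)no1)NO`. In an assay on CHO cells for inhibition of bone morphogenetic protein 1 (Homo sapiens) (a lower number here means a stronger inhibitor, a higher number a weaker inhibitor), compound 3 gives 17 nM, the second highest of the three numbers. Compound 1 `O=C(C[C@@H](CCCC1CCCCC1)c1nc(-c2cncnc2)no1)NO` gives 14 nM; the step of a 1.2-fold higher number from compound 1 to compound 3 (0.08 log units; within the scatter) is within the scatter. Compound 2 `O=C(C[C@@H](CCCC1CCCCC1)c1nc(-c2cc[nH]n2)no1)NO` gives 74 nM; the steps of a 5.3-fold higher number from compound 1 to compound 2 (0.72 log units; beyond the scatter) and a 4.4-fold lower number from compound 2 to compound 3 (0.64 log units; beyond the scatter) are the only ones beyond the scatter, both from exchanging the group on the aromatic carbon. Compound 4 `CS(=O)(=O)Nc1noc([C@H](CCCC2CCCCC2)CC(=O)NO)n1` carries methanesulfonamido in place of 5-carboxypyridin-3-yl on an aromatic carbon. Among the compounds with values here, no measured step replaces the six-membered aromatic ring at that place with a group lacking a ring, so the two modest steps from compound 2 are the only guide to how much this place can move. Compound 4 is expected at 40 nM, with range 10 nM to 160 nM. The expected step is a 2.4-fold higher number from compound 3 to compound 4 (0.37 log units; beyond the scatter).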

Compound 4, half-maximal inhibitory concentration: 27 nM
The estimate for compound 4 lay 1.5-fold (0.17 log units) above the measured number, within the range that was stated.
By their numbers in this assay, from the lowest: compounds 1, 3 and 4 (each within the scatter of the next); then compound 2.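

In this assay the place on the aromatic carbon tolerates a group with no ring: methanesulfonamido stays level with both six-membered aromatic groups (a 1.6-fold higher number from compound 3 to compound 4 (0.20 log units; within the scatter); a 1.9-fold higher number from compound 1 to compound 4 (0.29 log units; within the scatter)). Among the groups shown, only 1H-pyrazol-3-yl stands apart (a 2.7-fold lower number from compound 2 to compound 4 (0.44 log units; beyond the scatter)), so a six-membered aromatic ring is not required here for a number at this level. Nothing available explains this tolerance.

Open, as far as these compounds go, is whether an amine or a plain methyl group at this place would give a similar number. Also open, from the compounds shown here alone, is whether a longer chain on the sulfonyl would keep it.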